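The compounds below may be only part of what the source reports. "The series", "measured", "known", "first", "only" and "open" are said of these compounds alone.

Measured in a functional assay on WRL68 cells (Homo sapiens) for cytotoxicity, read by MTT assay, with stated times of 6 h and 48 h; on this read-out lower numbers stand for stronger inhibition and higher numbers for weaker inhibition:
- compound 1 `Cn1c(/C=C/C(=O)c2ccccc2O)cc(Br)c1Br` gives 330 nM
- compound 2 `Cn1c(/C=C/C(=O)c2ccccc2)cc(Br)c1Br` gives >= 100000 nM, a limit and not a number

Compound 2 stands at the limit of >= 100000 nM in this assay, at which 1 of the 2 values shown sits. Any step from it therefore starts from a limit and not from a true value.

Compound 3 `Cn1c(/C=C/C(=O)c2cccc(N)c2)cc(Br)c1Br` differs from compound 2 by amino in place of hydrogen on an aromatic carbon, meta to a large group: amino in place of hydrogen on an aromatic carbon.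

For the measured compounds named here, one measured step bears on this change: an at least 300-fold higher number from compound 1 to compound 2 (2.48 log units; beyond the scatter), a large step in which hydrogen replaces hydroxy on an aromatic carbon. Hydroxy is not amino, so that step offers only a loose guide. On the evidence of an at least 300-fold higher number from compound 1 to compound 2 (2.48 log units; beyond the scatter), a move to lower numbers in this assay is expected, probably smaller than that step and with a real chance of staying at the limit.

The expected step is an at least 6.6-fold lower number from compound 2 to compound 3 (0.82 log units; beyond the scatter).

Compound 3 is estimated at 15000 nM, with an expected range from 1000 nM to 100000 nM.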

Compound 3, half-maximal inhibitory concentration: >= 100000 nM
Compound 3: only a limit was reported; the forecaster's own chance of this, stated with the estimate: 35%; at least 6.6-fold (0.82 log units) between middle value and limit.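

In this assay compound 3 gives >= 100000 nM, a limit and not a number. Compound 2 also sits at a limit, so no step between compound 2 and compound 3 can be read: the limit of >= 100000 nM in this assay, at which 2 of the 3 values shown sit.

The compounds shown leave open whether amino in place of hydrogen on an aromatic carbon changes the read-out at all.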